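Removing one methyl from the side chain of compound 3

The source may hold more compounds than are shown below. What is called first, only, known or untested is meant among the compounds shown, and "the series" means these compounds.

Among the measured compounds shown here, in an ADME assay on A549 cells (Homo sapiens) for cytotoxicity, read by resazurin assay, with a stated time of 48 h (a higher number here means that more compound is tolerated, a lower number that less compound is tolerated), compound 3 `CC(CCO)Nc1ccc(NC(=O)c2cc(Cl)ccc2O)c(Cl)c1` gives 200000 nM, the highest of the three numbers measured so far. Compound 1 `O=C(Nc1ccc(NCc2ccc(C(F)(F)F)cc2)cc1Cl)c1cc(Cl)ccc1O` gives 62700 nM, and compound 2 `O=C(Nc1ccc(NCc2cc(F)cc(Cl)c2)cc1Cl)c1cc(Cl)ccc1O` gives 11100 nM. Compound 4 `O=C(Nc1ccc(NCCCO)cc1Cl)c1cc(Cl)ccc1O` is still unmeasured. It differs from compound 3 by hydrogen in place of methyl on a saturated chain carbon bound to a nitrogen on an aromatic ring and a saturated chain carbon, which turns 3-hydroxy-1-methylpropyl into 3-hydroxypropyl. For the measured compounds named here, no measured step tests this change directly. The largest step, an 18-fold higher number from compound 2 to compound 3 (1.26 log units; beyond the scatter), came with 3-hydroxy-1-methylpropyl in place of 3-chloro-5-fluorobenzyl. The modest step, a 5.6-fold lower number from compound 1 to compound 2 (0.75 log units; beyond the scatter), came with 3-chloro-5-fluorophenyl in place of 4-(trifluoromethyl)phenyl. Both exchanges involve far more of the molecule than a single methyl, so they offer only weak guidance here, and neither suggests a direction. No step beyond the scatter is therefore expected in this assay, and the estimated step is a 1.1-fold lower number from compound 3 to compound 4 (0.05 log units; within the scatter). For compound 4 the estimated value is 180000 nM, with an expected range of 80000 nM to 400000 nM.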

Compound 4, half-maximal cytotoxic concentration: 106000 nM
Beside the measured number, compound 4's estimate is 1.7-fold (0.23 log units) above it, and the stated range covers the measured number.
By their numbers in this assay, from the lowest: compound 2; then compounds 1, 4 and 3 (each within the scatter of the next, the first and the last beyond it).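

Taking the methyl off this saturated chain carbon gives a 1.9-fold lower number from compound 3 to compound 4 (0.28 log units; within the scatter) in this assay, so at this position hydrogen and methyl cannot be told apart in this read-out. The comparison with the aryl compounds divides: a 9.5-fold higher number from compound 2 to compound 4 (0.98 log units; beyond the scatter) is beyond the scatter, while a 1.7-fold higher number from compound 1 to compound 4 (0.23 log units; within the scatter) is within it. Exchanging an aryl group for 2-hydroxyethyl on this carbon therefore gives no general gain, and compound 1 goes against any such rule. Nothing shown here explains these steps.

The compounds shown leave open whether a longer chain, or an ethyl group on the same carbon, would stay within the scatter of compound 4. On these data alone, it also remains open how an amine or a carboxylic acid in place of the hydroxy group of 3-hydroxypropyl would read here.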